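Trifluoromethyl in place of chloro: working notes

The source may report more compounds than this note shows. Statements on the series, on what has been measured and on what is new or still open speak of the compounds shown alone.

Measured in a functional assay on CCRF-CEM cells (Homo sapiens) for inhibition, read by MTT assay, with a stated time of 72 h; on this read-out lower numbers stand for stronger inhibition and higher numbers for weaker inhibition:
- compound 1 `COc1cc(NC(C)CCCNC(=O)Nc2ccc(Br)cc2)c2ncccc2c1`: 23000 nM
- compound 2 `COc1cc(NC(C)CCCNC(=O)NNC(=O)Nc2ccc(F)cc2)c2ncccc2c1`: 118000 nM
- compound 3 `COc1cc(NC(C)CCCNC(=O)NNC(=O)Nc2ccc(Cl)cc2)c2ncccc2c1`: 108000 nM

Compound 3 gives 108000 nM, within the scatter of compound 2 and clearly higher than compound 1. The next compound to be measured is compound 4 `COc1cc(NC(C)CCCNC(=O)NNC(=O)Nc2ccc(C(F)(F)F)cc2)c2ncccc2c1`, which carries trifluoromethyl in place of chloro on an aromatic carbon.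

The closest measured precedent is the change of chloro for fluoro on an aromatic carbon, a 1.1-fold lower number from compound 2 to compound 3 (0.04 log units; within the scatter). That step lies within the scatter. The steps of a 5.1-fold higher number from compound 1 to compound 2 (0.71 log units; beyond the scatter) and a 4.7-fold higher number from compound 1 to compound 3 (0.67 log units; beyond the scatter) are modest and beyond the scatter, but they replace the 4-bromophenyl on an amide-type nitrogen and so bear only indirectly on this change. Among the compounds with values here, no trifluoromethyl compound has been measured yet, so the range stays wide.

The estimated change is a 1.2-fold lower number from compound 3 to compound 4 (0.08 log units; within the scatter), so no step beyond the scatter is expected in this assay. For compound 4 the expected value is 90000 nM, with an estimated range of 40000 nM to 190000 nM.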

Compound 4, half-maximal inhibitory concentration: 18000 nM
Estimate against measurement, compound 4: 5.0-fold (0.70 log units) above; the measured number lies below the stated range.
By their numbers in this assay, from the lowest: compounds 4 and 1 (each within the scatter of the next); then compounds 3 and 2 (each within the scatter of the next).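

In this assay the aromatic carbon para to a large group turns out to respond to its substituent: trifluoromethyl in place of chloro gives a 6.0-fold lower number from compound 3 to compound 4 (0.78 log units; beyond the scatter) and trifluoromethyl in place of fluoro gives a 6.6-fold lower number from compound 2 to compound 4 (0.82 log units; beyond the scatter) whereas chloro in place of fluoro gave only a 1.1-fold lower number from compound 2 to compound 3 (0.04 log units; within the scatter) and stayed within the scatter. The flat reading from the two halogens therefore holds for that pair alone and does not extend to this position as a whole. Nothing measured here accounts for the difference between trifluoromethyl and the two halogens.

Going by these compounds, whether a nitrile, a methyl or a carboxylic acid at this place would track with trifluoromethyl or with the halogens remains open. Also open, on these data alone, is whether the same change would give a similar step on the shorter urea chain of compound 1.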